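Carbonyl substituent change from compound 1 to compound 3

The source may report more compounds than this note shows. Statements on the series, on what has been measured and on what is new or still open speak of the compounds shown alone.

In a functional assay on MDA-MB-231 cells (Homo sapiens) for antiproliferative activity, read by MTT assay, with a stated time of 48 h (a higher number here means a weaker inhibitor, a lower number a stronger inhibitor), compound 1 `Cc1c(C(=O)OCCCN(C)C)oc2ccc(N(Cc3ccc(Br)cc3)S(=O)(=O)c3ccc(Br)cc3)cc12` gives 28600 nM and compound 2 `Cc1c(C(=O)NCC(O)CO)oc2ccc(N(Cc3ccc(Br)cc3)S(=O)(=O)c3ccc(Br)cc3)cc12` gives 16500 nM, two values within the scatter of each other. Compound 3 `Cc1ccc(NC(=O)c2oc3ccc(N(Cc4ccc(Br)cc4)S(=O)(=O)c4ccc(Br)cc4)cc3c2C)nc1` carries (5-methylpyridin-2-yl)amino in place of 3-(dimethylamino)propoxy on a carbonyl carbon. Among the measured compounds shown here, the one measured step at this place, a 1.7-fold lower number from compound 1 to compound 2 (0.24 log units; within the scatter), lies within the scatter. For the measured compounds named here, no measured compound has an aromatic ring entering here, so the evidence is thin. In this assay the expected result is no change beyond the scatter, an estimated 1.6-fold lower number from compound 1 to compound 3 (0.20 log units; within the scatter). The estimate for compound 3 is 18000 nM, with an expected range of 7000 nM to 45000 nM.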

Compound 3, half-maximal inhibitory concentration: > 40000 nM
Compound 3: a limit, no number; the forecaster's own chance of this, stated with the estimate: 15%; middle value at least 2.2-fold (0.34 log units) from the limit.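

In this assay compound 3 gives a limit of the assay and not a number: the limit of > 40000 nM in this assay, at which 1 of the 3 values shown sits.
Among the compounds shown here, with (5-methylpyridin-2-yl)amino on the carbonyl carbon, the series shows an at least 2.4-fold higher number from compound 2 to compound 3 (0.38 log units; beyond the scatter) and this is the first step at this place to pass the scatter. Against 3-(dimethylamino)propoxy the reading is an at least 1.3-fold higher number from compound 1 to compound 3 (0.14 log units; that floor lies within the scatter) so only a floor is known for that change.

From the compounds shown here alone, it remains open whether the higher number follows the aromatic ring, its methyl or its ring nitrogen. A plain phenylamino or an unsubstituted pyridin-2-ylamino on the same carbonyl carbon would separate these.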